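Cyano for tert-butyl on a biphenyl amine

The source may hold more compounds than are shown below. What is called first, only, known or untested is meant among the compounds shown, and "the series" means these compounds.

Measured compounds:
compound 1 `Oc1ccccc1CNc1ccc(-c2ccccc2)cc1`: 1820 nM
compound 2 `Oc1ccccc1CNc1ccc(-c2ccc(Cl)cc2)cc1`: 2390 nM
compound 3 `CC(C)(C)c1ccc(-c2ccc(NCc3ccccc3O)cc2)cc1`: "not active" (no number reported)

In a functional assay on Jurkat cells (Homo sapiens) for activation, with a stated time of 24 h (a lower number here means that less compound is needed, a higher number that more compound is needed for the effect), compound 3 stands apart from the other two: it gave no number and was reported as "not active" (no number reported), so it has no measured place on the scale. Compound 4 `N#Cc1ccc(-c2ccc(NCc3ccccc3O)cc2)cc1` differs from it by cyano in place of tert-butyl on an aromatic carbon. Going by the values given here, the only measured step, a 1.3-fold higher number from compound 1 to compound 2 (0.12 log units; within the scatter), changes the same outer ring and stayed within the scatter. Among the compounds with values here, no step touches a cyano or a tert-butyl, so the expectation leans on compounds 1 and 2. Compound 4 is expected near 3000 nM, within a range of 900 nM to 15000 nM, with a real chance of another result without a number.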

Compound 4, half-maximal effective concentration: "not active" (no number reported)
Compound 4: no number reported; there is nothing to compare the estimate with.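

Going by these compounds alone, compound 3 and compound 4 both lack a number in this assay, and no step between them can be read. No measurement shown bears on this result. Still open, going by these compounds, is whether cyano and tert-butyl differ at all in this assay.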